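Swapping a methylated tetrazole for its bare ring

The compounds below may be only part of what the source reports. "The series", "measured", "known", "first", "only" and "open" are said of these compounds alone.

Of the compounds shown here, two have so far been measured in an assay on a protein complex (Cavia porcellus) with sulfonylurea receptors; K-ATP channels (Homo sapiens) as the target; a lower number here means a stronger inhibitor, a higher number a weaker inhibitor. Compound 1 `Cn1nnnc1-c1ccc(NC(=O)C(C)(O)C(F)(F)F)cc1` gives 30900 nM, the higher of the two numbers, and compound 2 `CC(O)(C(=O)Nc1ccc(S(=O)(=O)N2CCOCC2)cc1)C(F)(F)F` gives 5850 nM, a gap that lies beyond the usual scatter of repeated measurements. Compound 3 `CC(O)(C(=O)Nc1ccc(-c2nn[nH]n2)cc1)C(F)(F)F` has not yet been tested in this assay. It differs from compound 1 in a single place: 2H-tetrazol-5-yl in place of 1-methyl-1H-tetrazol-5-yl on an aromatic carbon. For the measured compounds named here, no measured pair in this small set carries the same change, so there is nothing to copy a step size from; the change itself is modest in what it counts, one methyl group removed and one hydrogen-bond donor gained. The expected step is a 1.2-fold lower number from compound 1 to compound 3 (0.09 log units; within the scatter), which is no larger than the scatter. Compound 3 is therefore estimated at 25000 nM, with a likely range from 8000 nM to 80000 nM.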

Compound 3, half-maximal inhibitory concentration: > 30000 nM
Compound 3 gave a limit, no number; the forecaster's own chance of this, stated with the estimate: 15%; at least 1.2-fold (0.07 log units) between middle value and limit.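

In this assay compound 3 gives > 30000 nM, which is a limit of the assay and not a number. The step from compound 1 to compound 3 therefore cannot be read. The compounds shown leave open whether 2H-tetrazol-5-yl in place of 1-methyl-1H-tetrazol-5-yl changes the number at all.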